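The compounds below may be only part of what the source reports. "The series", "measured", "known", "first", "only" and "open" are said of these compounds alone.

In a functional assay on HepG2 cells (Homo sapiens) for cytotoxicity, read by sulforhodamine B assay, with a stated time of 24 h (on this read-out lower numbers stand for stronger inhibition and higher numbers for weaker inhibition), compounds built on one shared core have so far given a spread of numbers. Compound 2 `CC(=O)N/N=C1\C(=O)Nc2ccc(S(=O)(=O)N3CCOCC3)cc21` stands highest of the three at 27500 nM. Compound 1 `N=c1oc2ccccc2cc1C(=O)N/N=C1\C(=O)Nc2ccc(S(=O)(=O)N3CCOCC3)cc21` gives 7820 nM, and compound 3 `O=C1Nc2ccc(S(=O)(=O)N3CCOCC3)cc2/C1=N/c1ccc(/N=C2\C(=O)Nc3ccc(S(=O)(=O)N4CCOCC4)cc32)cc1` gives 8840 nM. The next structure, compound 4 `O=C1Nc2ccc(S(=O)(=O)N3CCOCC3)cc2/C1=N/c1ccc(Cl)cc1`, departs from compound 2 by putting 4-chlorophenyl in place of acetamido on a double-bonded nitrogen. Within the data shown here, one measured step bears on this indirectly, though at a different place, on a carbonyl carbon: a 3.5-fold higher number from compound 1 to compound 2 (0.55 log units; beyond the scatter), beyond the scatter, where the large ring-bearing group is lost. More direct is compound 3, which also has a six-membered aromatic ring of carbon only on a double-bonded nitrogen and gives 8840 nM. A modest step towards a lower number is therefore expected in this assay, of about the size seen between compound 1 and compound 2. The expected change is a 2.8-fold lower number from compound 2 to compound 4 (0.44 log units; beyond the scatter). For compound 4 the estimated value is 10000 nM, with an expected range from 4000 nM to 25000 nM.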

Compound 4, half-maximal inhibitory concentration: 11800 nM
Beside the measured number, compound 4's estimate is 1.2-fold (0.07 log units) below it; the measured number falls inside the stated range.
By their numbers in this assay, from the lowest: compounds 1, 3 and 4 (each within the scatter of the next); then compound 2.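

In this assay the swap on the double-bonded nitrogen gives a 2.3-fold lower number from compound 2 to compound 4 (0.37 log units; beyond the scatter) and so shows that this position, not only the carbonyl carbon of the earlier step, responds to a change of group. Replacing acetamido, with its hydrogen-bond donor and acceptor, by 4-chlorophenyl, which has neither, brings the number within the scatter of compound 3 at 8840 nM even though the group on that nitrogen is much smaller there in compound 4. Nothing measured here explains this step.

Going by these compounds, it remains open whether the six-membered aromatic ring alone accounts for the step or whether the chlorine contributes, as a plain phenyl would show. A 4-aminophenyl or 4-carboxyphenyl group, or a saturated cyclohexyl ring, on the same nitrogen would test how far the position tolerates other groups.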